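This account rests on a few compounds, and the source may have more. Where it says the series, first, only, none or still open, it means among the compounds named here.

Values in a functional assay on PC-3 cells (Homo sapiens) for cytotoxicity; on this read-out higher numbers stand for weaker inhibition and lower numbers for stronger inhibition:
Compound 1 `Nc1[nH]nc2nncc(-c3ccccc3)c12`: "not determined" (no result reported)
Compound 2 `Nc1nn(Cc2ccccc2)c2nnc(-c3ccccc3)c(-c3ccccc3)c12`: > 100000 nM
Compound 3 `O=C(Nc1ccccc1)Nc1[nH]nc2nnc(-c3ccccc3)c(-c3ccccc3)c12`: > 100000 nM

Compound 2 stands at > 100000 nM, which is a limit of this assay and not a number. Compound 3 also stands at a limit, > 100000 nM. Compound 1 has no result to compare.

Compound 4 `Nc1nn(CCOCCO)c2nnc(-c3ccccc3)c(-c3ccccc3)c12` is not yet measured. It carries (2-hydroxyethoxy)methyl in place of phenyl on a saturated chain carbon bound to an aromatic nitrogen. Cut one bond further out, this reads benzyl to 2-(2-hydroxyethoxy)ethyl.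

Among the measured compounds shown here, no measured step covers this change, and the only guide is the limit of > 100000 nM in this assay, at which 2 of the 3 values shown sit. Expected is a number no higher from compound 2 to compound 4 (the limit leaves the size open), meaning no change beyond the scatter, with any real shift expected toward stronger inhibition. For compound 4 the estimate is 100000 nM, with an expected range of 30000 nM to 300000 nM.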

Compound 4, half-maximal inhibitory concentration: > 100000 nM
Compound 4: only a limit was reported; the forecaster's own chance of this, stated with the estimate: 75%; the middle value sits exactly at the limit.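

In this assay compound 4 stands at > 100000 nM, which is a limit and not a number. Among the compounds shown here, no step from compound 2 to compound 4 can be read, as compound 2 also stands at a limit. The compounds shown leave open whether benzyl or 2-(2-hydroxyethoxy)ethyl gives any measurable inhibition.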